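Adding Fluoro Ortho to a Chloro Group on Compound 1

The source may report more compounds than this note shows. Statements on the series, on what has been measured and on what is new or still open speak of the compounds shown alone.

Going by the values given here, compound 1 `COc1cc2ncnc(Nc3cccc(Cl)c3)c2cc1OCCCCC(=O)Nc1ccc(S(N)(=O)=O)cc1` is the only member of this small set with a number rather than a limit: in a functional assay on A549 cells (Homo sapiens) for antiproliferative activity, read by MTT assay, with a stated time of 72 h (on this read-out higher numbers stand for weaker inhibition and lower numbers for stronger inhibition), compound 1 gives 11200 nM. Compound 2 `COc1cc2ncnc(Nc3ccc(F)cc3)c2cc1OCCCCC(=O)Nc1ccc(S(N)(=O)=O)cc1` reaches only a limit of the assay, giving > 40000 nM in this assay. Compound 3 `COc1cc2ncnc(Nc3ccc(Br)cc3)c2cc1OCCCCC(=O)Nc1ccc(S(N)(=O)=O)cc1` likewise reaches only a limit, giving > 40000 nM in this assay. The two replacements of 3-chlorophenyl on a nitrogen on an aromatic ring therefore read as an at least 3.5-fold higher number from compound 1 to compound 2 (0.55 log units; beyond the scatter) and an at least 3.5-fold higher number from compound 1 to compound 3 (0.55 log units; beyond the scatter), both set by the limit of > 40000 nM in this assay, at which 2 of the 3 values shown sit. The step between compound 2 and compound 3 is a step that the two limits leave unreadable from compound 2 to compound 3.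

Compound 4 `COc1cc2ncnc(Nc3cccc(Cl)c3F)c2cc1OCCCCC(=O)Nc1ccc(S(N)(=O)=O)cc1` differs from compound 1 by fluoro in place of hydrogen on an aromatic carbon. Among the compounds with values here, none of the measured steps alters the 3-chlorophenyl group in this way; they replace it with 4-fluorophenyl or 4-bromophenyl, and both weaken the compound by at least a modest amount. The new step keeps the chloro group and only adds fluoro, so the account expects a change within or close to the scatter, with a slight lean toward weaker inhibition. Compound 4 is therefore estimated at 15000 nM in this assay, with a range from 5000 nM to 40000 nM. This corresponds to an expected step of a 1.3-fold higher number from compound 1 to compound 4 (0.13 log units; within the scatter).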

Compound 4, half-maximal inhibitory concentration: 10500 nM
The estimate for compound 4 lay 1.4-fold (0.15 log units) above the measured number, and the stated range covers the measured number.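

Fluoro ortho to a chloro group proves a silent change at this position in this assay, the step reading a 1.1-fold lower number from compound 1 to compound 4 (0.03 log units; within the scatter), so the 3-chlorophenyl group can become 3-chloro-2-fluorophenyl with no readable shift, something the earlier steps, which only exchanged the whole aryl group, could not show. Compound 4 also separates from the two compounds carrying a single halogen on the other ring position, with an at least 3.8-fold lower number from compound 2 to compound 4 (0.58 log units; beyond the scatter) and an at least 3.8-fold lower number from compound 3 to compound 4 (0.58 log units; beyond the scatter), so the gap that compound 1 had to those compounds remains when this fluoro is present. Both of these sizes are only bounds, and the true gaps may be wider: the limit of > 40000 nM in this assay, at which 2 of the 4 values shown sit.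

The compounds shown leave open whether this aromatic carbon stays as indifferent to a group other than fluoro, such as methyl, methoxy or an amine, or whether only a small atom passes without a readable step. They also leave open whether a change elsewhere, such as a longer chain in place of the one that carries the sulfonamide-bearing amide, would move the number further from that of compound 1 than this fluoro does.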